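Halogen swap on the carbonyl-linked phenyl ring

The source may hold more compounds than are shown below. What is called first, only, known or untested is meant among the compounds shown, and "the series" means these compounds.

Measured so far:
- compound 1 `COc1ccccc1C(=O)c1sc2nc(-c3cccs3)ccc2c1N`: 0.059 ug/mL
- compound 2 `Nc1c(C(=O)c2cccc(F)c2)sc2nc(-c3cccs3)ccc12`: 0.025 ug/mL

Both values come from a functional assay on WI-38 VA13 cells (Homo sapiens) for cytotoxicity; on this read-out lower numbers stand for an effect already at smaller amounts and higher numbers for an effect only at larger amounts of compound. Compound 2 holds the lowest of the two numbers; its nearest neighbour is compound 1, and the step of a 2.4-fold lower number from compound 1 to compound 2 (0.37 log units; beyond the scatter) is modest but beyond the scatter. That step is the only one measured, and it exchanges the whole aryl group on the carbonyl carbon.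

Compound 3 `Nc1c(C(=O)c2cccc(Br)c2)sc2nc(-c3cccs3)ccc12` is still to be measured in this assay. Relative to compound 2 the change is bromo in place of fluoro on an aromatic carbon. Going by the values given here, no measured step bears on a halogen-for-halogen exchange at this position; the one step known, from compound 1 to compound 2, concerns a different aryl group and gives no guidance on the size or direction here. The expectation is therefore no step beyond the scatter, with the estimate for compound 3 set at 0.03 ug/mL (range 0.01 ug/mL to 0.09 ug/mL), which means an expected step of a 1.2-fold higher number from compound 2 to compound 3 (0.08 log units; within the scatter).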

Compound 3, half-maximal effective concentration: 0.5 ug/mL
Estimate against measurement, compound 3: 17-fold (1.22 log units) below; measured number above the stated range.
By their numbers in this assay, from the lowest: compound 2; then compound 1; then compound 3.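

In this assay this place on the ring proves sensitive to the identity of the halogen: a 20-fold higher number from compound 2 to compound 3 (1.30 log units; beyond the scatter), a large step from exchanging a single heavy atom, with no ring, hydrogen-bond donor or acceptor entering or leaving. The aryl group on the carbonyl carbon can also move the number in either direction relative to the 2-methoxyphenyl compound, since 3-fluorophenyl gave the lower number and 3-bromophenyl gives an 8.5-fold higher number from compound 1 to compound 3 (0.93 log units; beyond the scatter). No available evidence accounts for the gap between fluoro and bromo here.

With only two halogens at this place, the compounds shown set no trend, and where chloro would fall remains open. Also open, going by these compounds, is how a non-halogen group on the same ring carbon, such as an amine or a carboxylic acid, would read out.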